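Phenyl in place of dimethylamino in the series

The source may report more compounds than this note shows. Statements on the series, on what has been measured and on what is new or still open speak of the compounds shown alone.

Measured in an ADME assay on J774.1 cells (Mus musculus) for cytotoxicity, read by resazurin assay, with a stated time of 48 h; on this read-out lower numbers stand for stronger inhibition and higher numbers for weaker inhibition:
- compound 1 `CCCCn1cc(C(=O)NCc2ccccc2)c(=O)c2cc(F)c(N(C)C)cc21`: > 100000 nM
- compound 2 `CCn1cc(C(=O)NCc2ccc(OC)cc2)c(=O)c2ccc(C(F)(F)F)cc21`: > 100000 nM

Compound 1 stands at a limit, > 100000 nM, and not at a number. Compound 2 also gives only a limit, > 100000 nM. Among the measured compounds shown here, no step between measured compounds is available in this assay.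

Compound 3 `CCCCn1cc(C(=O)NCc2ccccc2)c(=O)c2cc(F)c(-c3ccccc3)cc21` keeps the rest of compound 1 and changes one group: phenyl in place of dimethylamino on an aromatic carbon. This is phenyl in place of dimethylamino on an aromatic carbon, ortho to a fluoro group.

For the measured compounds named here, the only guide to the expectation is the limit of > 100000 nM in this assay, at which 2 of the 2 values shown sit. The expected change is an at least 1.4-fold lower number from compound 1 to compound 3 (0.15 log units; that floor lies within the scatter), a modest one towards stronger inhibition, and this assay may show none. For compound 3 the estimated value is 70000 nM, with an expected range from 25000 nM to 100000 nM, and a result reported only as a limit would not surprise.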

Compound 3, half-maximal inhibitory concentration: > 100000 nM
Compound 3 ended at the assay's limit (the forecaster's own chance of this, stated with the estimate: 60%); middle value at least 1.4-fold (0.15 log units) from the limit.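

No step can be read between compound 1 and compound 3 in this assay, since both results are limits: the limit of > 100000 nM in this assay, at which 3 of the 3 values shown sit.

The compounds shown leave open whether phenyl in place of dimethylamino changes cytotoxicity at all, and at what concentration any of them would reach half-maximal inhibition.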